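The compounds below may be only part of what the source reports. "The series", "measured", "known", "first", "only" and "open" are said of these compounds alone.

In a functional assay on MOLT-4 cells (Homo sapiens) for inhibition (on this read-out lower numbers stand for stronger inhibition and higher numbers for weaker inhibition), compound 1 `O=C1/C(=C/c2ccc(Cl)cc2)Cc2ccccc21` gives > 500000 nM, which is a limit of the assay and not a number. Compound 2 `O=C1CCCCC/C1=C\c1ccccc1` gives 215000 nM. Compound 3 `O=C1CCCCC/C1=C\c1cccc(Cl)c1` gives 88600 nM, the lower of the two actual numbers. Within the data shown here, the one measured step between close neighbours is a 2.4-fold lower number from compound 2 to compound 3 (0.39 log units; beyond the scatter), with chloro in place of hydrogen on an aromatic carbon, and it is modest.

Compound 4 `COc1cccc(/C=C2\CCCCCC2=O)c1` differs from compound 3 by methoxy in place of chloro on an aromatic carbon, meta to a group of 9 heavy atoms: methoxy in place of chloro on an aromatic carbon. Among the measured compounds shown here, no measured step makes this exchange directly, so the evidence is indirect. The chloro group of compound 3 stands on the same kind of carbon where the modest step of a 2.4-fold lower number from compound 2 to compound 3 (0.39 log units; beyond the scatter) was seen, and removing it in favour of methoxy may give back some or all of that gain. A small move toward a higher number in this assay is therefore expected, no larger than that earlier step. The estimated change is a 1.4-fold higher number from compound 3 to compound 4 (0.13 log units; within the scatter). For compound 4 the estimated value is 120000 nM, with an expected range from 55000 nM to 260000 nM.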

Compound 4, half-maximal inhibitory concentration: 170000 nM
Compound 4: middle estimate off by 1.4-fold (0.15 log units), on the low side; low and high end bracket the measured number.
By their numbers in this assay, from the lowest: compounds 3, 4 and 2 (each within the scatter of the next, the first and the last beyond it). At a limit, above all of these: compound 1.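

Methoxy in place of hydrogen on this aromatic carbon, meta to a group of 9 heavy atoms, gives a 1.3-fold lower number from compound 2 to compound 4 (0.10 log units; within the scatter) in this assay, so at this position the methoxy compound cannot be told apart from the unsubstituted one. Methoxy in place of chloro gives a 1.9-fold higher number from compound 3 to compound 4 (0.28 log units; within the scatter), so it cannot be told apart from the chloro compound either, although the chloro and hydrogen compounds are separated by a 2.4-fold lower number from compound 2 to compound 3 (0.39 log units; beyond the scatter); the three groups therefore fall into no clear order, and only that one pair stands apart beyond the scatter. No measurement at hand bears on what lies behind these numbers.

The compounds shown leave open whether a group of another kind on this same carbon, such as an amine, a carboxylic acid or a longer alkyl chain, would move the number further than chloro does. They also leave open whether methoxy or chloro would give a step beyond the scatter on another carbon of the aromatic ring, since all the steps here concern this one position on the shared core.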